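A few compounds are considered here, and "the series" means these few. Any claim that something is new, unique, unknown or untested is made for them only; others in the source may bear on it.

Of the compounds shown here, three with a shared core have been measured in an assay on cells for displacement of a labelled ligand from Orexin receptor type 2 (Homo sapiens), read by scintillation counting, with stated times of 10 min and 90 min, tested at 10 uM; on this read-out higher numbers stand for more inhibition at the one concentration tested (going by the name of the read-out) and lower numbers for less inhibition. Compound 1 `COC(=O)c1ccc2c(C(=O)c3ccccc3)cc(C(=O)c3ccccc3)c-2cc1` gives -14.5%, compound 2 `O=C(O)c1ccc2c(C(=O)c3ccccc3)cc(C(=O)c3ccccc3)c-2cc1` gives 27%, and compound 3 `COC(=O)Cc1ccc2ccc(C(=O)c3ccccc3)c-2cc1` gives -4.3%. Compound 3 thus stands second of the three: above compound 1 and well below compound 2, both gaps beyond the scatter. Among the compounds with values here, the one step measured in a single place, a number 41.5 percentage points higher from compound 1 to compound 2 (beyond the scatter), concerns the ester and not the ring. Compound 4 `COC(=O)Cc1ccc2c(C(=O)c3ccccc3)cc(C(=O)c3ccccc3)c-2cc1` differs from compound 3 by benzoyl in place of hydrogen on an aromatic carbon. Within the data shown here, no measured step isolates a benzoyl, so the only guide is that compound 1, which carries two benzoyl groups, sits modestly below compound 3. A small downward step is therefore expected, a number 3.7 percentage points lower from compound 3 to compound 4 (within the scatter), giving compound 4 an estimated -8% in this assay, within -25% to 10%.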

Compound 4, a percentage reported as inhibition, at one concentration (the size of the read-out at that concentration, not a potency): -20.4%
Estimate against measurement, compound 4: 12.4 percentage points above; low and high end bracket the measured number.
By their numbers in this assay, from the lowest: compounds 4 and 1 (each within the scatter of the next); then compound 3; then compound 2.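

This pair isolates benzoyl on an aromatic carbon of a five-membered aromatic ring: in this assay, adding it gives a number 16.1 percentage points lower from compound 3 to compound 4 (beyond the scatter). With (methoxycarbonyl)methyl in place of methoxycarbonyl the result is a number 5.9 percentage points lower from compound 1 to compound 4 (within the scatter), while the same group in place of carboxy gives a number 47.4 percentage points lower from compound 2 to compound 4 (beyond the scatter). Nothing available explains these results.

Still open, from the compounds shown here alone, is whether benzoyl has a similar effect when the core carries a carboxylic acid on a longer chain. An amine at this position might also give a different number.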